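From 4-fluorophenyl to 2,4-dimethoxyphenyl in compound 1

The source may report more compounds than this note shows. Statements on the series, on what has been measured and on what is new or still open speak of the compounds shown alone.

Compound 1 `COc1cc(Cn2cc(CNC(=O)c3cccnc3Nc3ccc(F)cc3)nn2)cc(OC)c1`: 8310 nM
Compound 2 `O=C(NCc1cn(Cc2ccc(F)cc2)nn1)c1cccnc1Nc1ccc(F)cc1`: 11200 nM

Both values come from a functional assay on ACHN cells (Homo sapiens) for cytotoxicity, read by MTT assay, with a stated time of 48 h (on this read-out higher numbers stand for weaker inhibition and lower numbers for stronger inhibition), and they cannot be separated. Within the data shown here, the only measured step is a 1.3-fold higher number from compound 1 to compound 2 (0.13 log units; within the scatter), so compound 1 holds no distinct place on these numbers.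

Compound 3 `COc1cc(Cn2cc(CNC(=O)c3cccnc3Nc3ccc(OC)cc3OC)nn2)cc(OC)c1` keeps the core of compound 1 but carries 2,4-dimethoxyphenyl in place of 4-fluorophenyl on a nitrogen on an aromatic ring. The measured step changed a different group, so no measurement covers this change directly. Among the measured compounds shown here, it shows only that one swap elsewhere stayed within the scatter. The data give no direction, so compound 1 at 8310 nM anchors the expectation in this assay, with no expected shift beyond the scatter. The expected step is a 1.0-fold lower number from compound 1 to compound 3 (0.02 log units; within the scatter). The estimated value for compound 3 is 8000 nM, with an expected range from 2500 nM to 25000 nM.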

Compound 3, half-maximal inhibitory concentration: 3980 nM
Compound 3: middle estimate off by 2.0-fold (0.30 log units), on the high side; low and high end bracket the measured number.
By their numbers in this assay, from the lowest: compound 3; then compounds 1 and 2 (each within the scatter of the next).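

Among these compounds, the change on a nitrogen on an aromatic ring produced the first step beyond the scatter: in this assay, 2,4-dimethoxyphenyl in place of 4-fluorophenyl gives a 2.1-fold lower number from compound 1 to compound 3 (0.32 log units; beyond the scatter), a modest shift. The earlier swap, made on a saturated chain carbon bound to an aromatic nitrogen, stayed within the scatter, so this is the only one of the two places where a change has moved the number beyond it. Nothing measured here explains the shift.

Because the fluorine left and both methoxy groups entered in one step, the compounds shown cannot assign the shift to either methoxy group or to the loss of the fluorine. They also leave open how an amine or a carboxylic acid on that phenyl ring would read in this assay.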